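This account rests on a few compounds, and the source may have more. Where it says the series, first, only, none or still open, it means among the compounds named here.

compound 1 `CCC(c1ccc2ncccc2c1F)n1cnc2ncc(-c3cnn(CCO)c3)nc21` – "not determined" (no result reported)
compound 2 `Cn1nccc1-c1cnc2ncn(Cc3ccc4ncccc4c3)c2n1` – 7910 nM

For the measured compounds named here, in a functional assay on NCI-H1993 cells (Homo sapiens) for inhibition, read by CCK-8 assay, with a stated time of 72 h (a higher number here means a weaker inhibitor, a lower number a stronger inhibitor), compound 2 gives 7910 nM as the only number, so it has no rank against another compound. Compound 3 `c1cnc2ccc(Cn3cnc4ncc(-c5cn[nH]c5)nc43)cc2c1` differs from it in one place on the shared core: 1H-pyrazol-4-yl in place of 1-methyl-1H-pyrazol-5-yl on an aromatic carbon. Going by the values given here, no measured step is available to size this change, so the expectation is uncertain. The estimate is a 53-fold lower number from compound 2 to compound 3 (1.72 log units; beyond the scatter) in this assay as a large move toward stronger inhibition, beyond the scatter. Compound 3 is expected at 150 nM with 15 nM to 1500 nM as the estimated range.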

Compound 3, half-maximal inhibitory concentration: 2890 nM
Compound 3: middle estimate off by 19-fold (1.28 log units), on the low side; the measured number lies above the stated range.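

The change from 1-methyl-1H-pyrazol-5-yl to 1H-pyrazol-4-yl on this aromatic carbon gives the series its first sized step in this assay: a 2.7-fold lower number from compound 2 to compound 3 (0.44 log units; beyond the scatter), modest but beyond the scatter. The step combines loss of the methyl, a moved ring attachment and the gain of a hydrogen-bond donor, and this single pair cannot separate them. No measured evidence bears on the cause of the shift.

Still open, from the compounds shown here alone, is whether 1-methyl-1H-pyrazol-4-yl would separate the methyl from the attachment. Also open, going by these compounds, is how a pyrazole carrying a longer chain ending in an amine or a carboxylic acid would read here.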